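Chain shortening on the aromatic nitrogen: compound 4

The source may report more compounds than this note shows. Statements on the series, on what has been measured and on what is new or still open speak of the compounds shown alone.

Three analogues on one shared core differ only in the chain on the aromatic nitrogen. Compound 1 `CC/C=C\Cn1c(Cc2cc(OC)c(OC)c(OC)c2)nc2c(N)ncnc21` gives 64600 nM in a functional assay on MCF7 cells (Homo sapiens) for antiproliferative activity; a lower number here means a stronger inhibitor, a higher number a weaker inhibitor; compound 2 `CCCn1c(Cc2cc(OC)c(OC)c(OC)c2)nc2c(N)ncnc21` gives 46800 nM; compound 3 `CCC(C)Cn1c(Cc2cc(OC)c(OC)c(OC)c2)nc2c(N)ncnc21` gives 61700 nM. Compound 3 stands second highest of the three numbers, and every pair sits within the scatter: a 1.0-fold lower number from compound 1 to compound 3 (0.02 log units; within the scatter) and a 1.3-fold higher number from compound 2 to compound 3 (0.12 log units; within the scatter), while the remaining pair shows a 1.4-fold lower number from compound 1 to compound 2 (0.14 log units; within the scatter). Compound 4 `CCn1c(Cc2cc(OC)c(OC)c(OC)c2)nc2c(N)ncnc21` carries the change (methyl in place of sec-butyl on a saturated chain carbon bound to an aromatic nitrogen). For the measured compounds named here, the steps that bear on it are the ones that already altered this chain: a 1.4-fold lower number from compound 1 to compound 2 (0.14 log units; within the scatter) and a 1.3-fold higher number from compound 2 to compound 3 (0.12 log units; within the scatter) both stayed within the scatter, so across compounds 1, 2 and 3 the number has not followed the size of the chain. The step to the shortest chain is therefore expected to stay within the scatter as well, in no particular direction: a 1.2-fold lower number from compound 3 to compound 4 (0.07 log units; within the scatter). Compound 4 is estimated at 52000 nM, with a range of 26000 nM to 105000 nM.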

Compound 4, half-maximal inhibitory concentration: 79400 nM
Estimate against measurement, compound 4: 1.5-fold (0.18 log units) below; low and high end bracket the measured number.
By their numbers in this assay, from the lowest: compounds 2, 3, 1 and 4 (each within the scatter of the next).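

Ethyl on the aromatic nitrogen adds the smallest chain of the set, and in this assay this change stays within the scatter (a 1.3-fold higher number from compound 3 to compound 4 (0.11 log units; within the scatter)). The same holds against the other two chains (a 1.7-fold higher number from compound 2 to compound 4 (0.23 log units; within the scatter); a 1.2-fold higher number from compound 1 to compound 4 (0.09 log units; within the scatter)), so all four compounds form a single flat set, and neither the length of the chain, its branch nor its double bond gives a readable difference in the number. No data at hand offer an explanation for this flat result.

Going by these compounds, all four chains are plain hydrocarbons, so the effect of an amine, a carboxylic acid or a hydroxyl group on the chain remains open. Also open, on these data alone, is whether a much longer chain, such as decyl, or a benzyl group at this position would move the number beyond the scatter.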